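This account rests on a few compounds, and the source may have more. Where it says the series, first, only, none or still open, it means among the compounds named here.

Measured so far:
compound 1 `O=C(O)c1cncc(C2CC2c2ccc(OCc3c(-c4c(Cl)cccc4Cl)noc3C3CC3)cc2Cl)c1` — 73%
compound 2 `O=C(O)c1ccc(C2CC2c2ccc(OCc3c(-c4c(Cl)cccc4Cl)noc3C3CC3)cc2Cl)cn1` — 68%

Both numbers come from an assay on HEK293 cells for agonist activity at Bile acid receptor (Homo sapiens); on this read-out lower numbers stand for smaller maximal responses and higher numbers for larger maximal responses. Compound 2 gives the lower of the two numbers in this assay; its nearest neighbour is compound 1, and the step between them, a number 5 percentage points lower from compound 1 to compound 2 (within the scatter), lies within the scatter. Compound 3 `O=C(O)c1cccc([C@@H]2C[C@H]2c2ccc(OCc3c(-c4c(Cl)cccc4Cl)noc3C3CC3)cc2Cl)c1` is not yet measured. It differs from compound 2 in one place: 2-(3-carboxyphenyl)cyclopropyl in place of 2-(6-carboxypyridin-3-yl)cyclopropyl on an aromatic carbon. For the measured compounds named here, no measured step covers this kind of change; the only step at hand, a number 5 percentage points lower from compound 1 to compound 2 (within the scatter), concerns the exchange of one carboxypyridinyl group for another and was small. The carboxylic acid and the three-membered ring are kept. Compound 3 is therefore expected to stay close to compound 2, with an expected step of a number 2 percentage points higher from compound 2 to compound 3 (within the scatter), not beyond the scatter. For compound 3 the estimate in this assay is 70%, with a range from 55% to 85%.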

Compound 3, largest response reached (reported as efficacy), in percent of the reference or control that the assay uses: 98%
Beside the measured number, compound 3's estimate is 28 percentage points below it, outside the stated range (above it).
By their numbers in this assay, from the lowest: compounds 2 and 1 (each within the scatter of the next); then compound 3.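

In this assay, the 2-(3-carboxyphenyl)cyclopropyl group stands apart from both carboxypyridinyl versions (a number 30 percentage points higher from compound 2 to compound 3 (beyond the scatter); a number 25 percentage points higher from compound 1 to compound 3 (beyond the scatter)), whereas the exchange between the two carboxypyridinyl versions gave a step within the scatter. At this place on the ring ortho to the chloro group, the response therefore depends on the group's six-membered aromatic ring or its defined stereocentres, neither of which the earlier pair varied. No accompanying measurement explains the step.

The data leave open how much of the step belongs to the ring of carbon only and how much to the defined stereocentres, and how the opposite stereoisomer of compound 3 would respond. Also open, going by these compounds, is whether a 4-carboxyphenyl group, or a tetrazole in place of the carboxylic acid, would keep the response of compound 3.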